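A few compounds are considered here, and "the series" means these few. Any claim that something is new, unique, unknown or untested is made for them only; others in the source may bear on it.

Compound 1 `C/C(=N\NC(=O)c1cccc(S(=O)(=O)N2CCOCC2)c1)c1ccccc1O` stands lowest of the three numbers measured in a functional assay on ECa-109 cells for antiproliferative activity against ECa-109 cell line (Homo sapiens), read by MTT assay, with a stated time of 72 h (on this read-out lower numbers stand for stronger inhibition and higher numbers for weaker inhibition), where compound 1 gives 5450 nM. Compound 2 `C/C(=N\NC(=O)c1cccc(S(=O)(=O)N2CCOCC2)c1)c1ccc(O)cc1` gives 88300 nM, and compound 3 `C/C(=N\NC(=O)c1cccc(S(=O)(=O)N2CCOCC2)c1)c1cc(O)ccc1O` gives 21400 nM. Shifting the hydroxy group cost heavily: a 16-fold higher number from compound 1 to compound 2 (1.21 log units; beyond the scatter). Adding a second hydroxy cost less: a 3.9-fold higher number from compound 1 to compound 3 (0.59 log units; beyond the scatter). Compound 4 `C/C(=N\NC(=O)c1cccc(S(=O)(=O)N2CCOCC2)c1)c1cc(F)ccc1O` differs from compound 1 by fluoro in place of hydrogen on an aromatic carbon. Among the compounds with values here, only one measured step bears on it, a 3.9-fold higher number from compound 1 to compound 3 (0.59 log units; beyond the scatter), a change that likewise swapped one of the ring hydrogens of compound 1 for a new substituent. Fluoro is a smaller group than hydroxy, so a milder weakening is expected: a 1.5-fold higher number from compound 1 to compound 4 (0.17 log units; within the scatter). Compound 4 is therefore estimated at 8000 nM, within a range from 3000 nM to 22000 nM.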

Compound 4, half-maximal inhibitory concentration: 3270 nM
Compound 4: middle estimate off by 2.4-fold (0.39 log units), on the high side; measured number inside the range.
By their numbers in this assay, from the lowest: compounds 4 and 1 (each within the scatter of the next); then compound 3; then compound 2.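

Within the data shown here, at the ring place para to the hydroxy group, fluoro is accepted in this assay: a 1.7-fold lower number from compound 1 to compound 4 (0.22 log units; within the scatter) stays within the scatter, which the earlier compounds could not show for this position. The group at this place matters, as fluoro in place of hydroxy gives a 6.5-fold lower number from compound 3 to compound 4 (0.82 log units; beyond the scatter), while the 5-fluoro-2-hydroxyphenyl group in place of 4-hydroxyphenyl gives a 27-fold lower number from compound 2 to compound 4 (1.43 log units; beyond the scatter). Nothing available explains these differences. From the compounds shown here alone, whether chloro, methoxy or an amine at this place would match fluoro remains open. So does whether fluoro elsewhere on the ring would be accepted in the same way.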